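This account rests on a few compounds, and the source may have more. Where it says the series, first, only, none or still open, it means among the compounds named here.

Working notes on the series sharing one core, read in a functional assay on PC-3 cells (Homo sapiens) for antiproliferative activity, read by MTT assay, with a stated time of 48 h; a higher number here means a weaker inhibitor, a lower number a stronger inhibitor. Compound 1 `COc1ccc(CN(C(=O)Cn2cc(COc3ccc4ccc(=O)oc4c3)nn2)c2cc(OC)c(OC)c(OC)c2)cc1` gives 860 nM, compound 2 `COc1ccc(CN(C(=O)Cn2cc(CSc3nc4ccccc4o3)nn2)c2cc(OC)c(OC)c(OC)c2)cc1` gives 5050 nM, and compound 3 `COc1ccc(CN(C(=O)Cn2cc(Cn3ccc4ccccc43)nn2)c2cc(OC)c(OC)c(OC)c2)cc1` gives 2390 nM, the second highest of the three numbers. Compound 4 `COc1ccc(CN(C(=O)Cn2cc(CNS(=O)(=O)c3ccc(C)cc3)nn2)c2cc(OC)c(OC)c(OC)c2)cc1` differs from compound 3 as follows: ((4-methylphenyl)sulfonyl)amino in place of 1H-indol-1-yl on a saturated chain carbon bound to an aromatic carbon. The measured steps all exchange the group at this same place: a 5.9-fold higher number from compound 1 to compound 2 (0.77 log units; beyond the scatter), a 2.8-fold higher number from compound 1 to compound 3 (0.44 log units; beyond the scatter) and a 2.1-fold lower number from compound 2 to compound 3 (0.32 log units; beyond the scatter). All are modest, and none involves ((4-methylphenyl)sulfonyl)amino, so they indicate a likely size but no direction. In this assay, no step beyond the scatter is therefore expected. The estimated outcome is a 1.0-fold higher number from compound 3 to compound 4 (0.02 log units; within the scatter). Compound 4 is expected at 2500 nM, with an estimated range of 800 nM to 8000 nM.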

Compound 4, half-maximal inhibitory concentration: 12400 nM
Compound 4: the middle estimate sits 5.0-fold (0.70 log units) below what was measured; measured number above the stated range.
By their numbers in this assay, from the lowest: compound 1; then compound 3; then compound 2; then compound 4.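

In this assay, ((4-methylphenyl)sulfonyl)amino on this saturated chain carbon gives the highest number of the series, with a 5.2-fold higher number from compound 3 to compound 4 (0.72 log units; beyond the scatter), a 2.5-fold higher number from compound 2 to compound 4 (0.39 log units; beyond the scatter) and a 14-fold higher number from compound 1 to compound 4 (1.16 log units; beyond the scatter) as its steps. Going by these compounds alone, the last of these is the first large step, so exchange at this position can move the number further than the earlier compounds showed. This group is also the only one of the four with a single ring.

Going by these compounds, whether the ring count or the sulfonyl link goes with the higher number stays open, and a simple amine or a carboxylic acid at this place would add a different kind of group. Nothing available explains the rise.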